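The source may hold more compounds than are shown below. What is called first, only, known or untested is meant among the compounds shown, and "the series" means these compounds.

Working notes on the series

Values in a functional assay on MCF7 cells (Homo sapiens) for cytotoxicity, read by MTT assay, with a stated time of 48 h; on this read-out lower numbers stand for stronger inhibition and higher numbers for weaker inhibition:
- compound 1, `CC(C)=CCC/C(C)=C/CC/C(C)=C/CC[C@@H]1[C@@]2(C)CC/C(=N\OCc3cn(-c4c(Cl)cc([N+](=O)[O-])cc4Cl)nn3)C(C)(C)[C@@H]2CC[C@@]1(C)O`: 16600 nM
- compound 2, `COc1cc(OC)c(-n2cc(CO/N=C3\CC[C@]4(C)[C@@H](CC/C=C(\C)CC/C=C(\C)CCC=C(C)C)[C@](C)(O)CC[C@H]4C3(C)C)nn2)c(OC)c1`: 14700 nM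
- compound 3, `CC(C)=CCC/C(C)=C/CC/C(C)=C/CC[C@@H]1[C@@]2(C)C/C(=C\c3ccc(OCc4cn(-c5c(Cl)cc([N+](=O)[O-])cc5Cl)nn4)cc3)C(=O)C(C)(C)[C@@H]2CC[C@@]1(C)O`: 27100 nM

The three numbers lie within the usual scatter of one another, so no order among compounds 1, 2 and 3 can be read from this assay.

Compound 1 and compound 3 are built on different cores; the difference between the two cores is not broken down here, since they differ in more than one place. Compound 1 and compound 2 differ in one place only: 2,4,6-trimethoxyphenyl in place of 2,6-dichloro-4-nitrophenyl on an aromatic nitrogen. That change gave a 1.1-fold lower number from compound 1 to compound 2 (0.05 log units; within the scatter), a step too small to count as a real shift.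

Compound 4, `COc1cc(OC)c(-n2cc(COc3ccc(/C=C4\C[C@]5(C)[C@@H](CC/C=C(\C)CC/C=C(\C)CCC=C(C)C)[C@](C)(O)CC[C@H]5C(C)(C)C4=O)cc3)nn2)c(OC)c1`, has not yet been measured. It stands to compound 3 exactly as compound 2 stands to compound 1: 2,4,6-trimethoxyphenyl in place of 2,6-dichloro-4-nitrophenyl on an aromatic nitrogen. The place of the change, on the aromatic nitrogen of the five-membered ring with three nitrogens, is the same in both pairs.

For compound 4 in this assay the expected step is a 1.1-fold lower number from compound 3 to compound 4 (0.04 log units; within the scatter), which rests on the flat result of the same change from compound 1 to compound 2, a 1.1-fold lower number from compound 1 to compound 2 (0.05 log units; within the scatter). The estimate for compound 4 is therefore 25000 nM, with a likely range of 12000 nM to 50000 nM; this is an expectation from one precedent only, and a reported limit instead of a number cannot be excluded at these concentrations.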

Compound 4, half-maximal inhibitory concentration: 13500 nM
Compound 4: the middle estimate sits 1.9-fold (0.27 log units) above what was measured; low and high end bracket the measured number.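

In this assay, among the compounds shown here, putting 2,4,6-trimethoxyphenyl in place of 2,6-dichloro-4-nitrophenyl on the aromatic nitrogen gave a 2.0-fold lower number from compound 3 to compound 4 (0.30 log units; within the scatter), so on this core too the change produces no step that can be told from the scatter. Set beside the earlier pair, the two results do not differ: the same change on two cores in this assay, a 1.1-fold lower number (0.05 log units; within the scatter) from compound 1 to compound 2 and a 2.0-fold lower number (0.30 log units; within the scatter) from compound 3 to compound 4, 1.8-fold (0.25 log units) apart, within the scatter of two such steps. Within these four compounds, the change therefore carries from one core to the other as a flat result, but this does not show that the aryl group on the aromatic nitrogen is without influence on this read-out, or that the result would stay flat on any further core, and two pairs in a single cell line give no general rule.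

The compounds shown carry only these two substituted phenyl groups on the aromatic nitrogen, so it remains open whether a basic amine, a carboxylic acid or a longer alkyl chain in that place would move the number beyond the scatter. Also open, going by these compounds, is whether the flat result of this exchange holds in cell lines other than the one used in this assay.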